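A methyl group added to the phenoxy ring of compound 3

A few compounds are considered here, and "the series" means these few. Any claim that something is new, unique, unknown or untested is made for them only; others in the source may bear on it.

compound 1 `Cc1ccc(-c2cnc(N(Cc3ccccc3)Cc3ccc(C(=O)NO)cc3)s2)cc1` gives 34000 nM
compound 2 `Cc1ccc(-c2cnc(N(Cc3ccc(C(=O)NO)cc3)CC(C)C)s2)cc1` gives 7420 nM
compound 3 `Cc1ccc(-c2cnc(N(CCCCOc3ccccc3)Cc3ccc(C(=O)NO)cc3)s2)cc1` gives 16600 nM

In a functional assay on HepG2 cells (Homo sapiens) for antiproliferative activity, read by MTT assay, with a stated time of 48 h (on this read-out lower numbers stand for stronger inhibition of growth and higher numbers for weaker inhibition of growth), compound 3 at 16600 nM holds the middle place among the three numbers, with compound 1 higher and compound 2 lower. These compounds differ only in one side chain on the shared core. Compound 4 `Cc1ccc(OCCCCN(Cc2ccc(C(=O)NO)cc2)c2ncc(-c3ccc(C)cc3)s2)cc1` keeps the chain of compound 3 but turns its phenoxy into 4-methylphenoxy, a change counted as methyl in place of hydrogen on an aromatic carbon and placed para to a large group.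

The measured steps bear on this only indirectly. Exchanging whole side chains gave a 4.6-fold lower number from compound 1 to compound 2 (0.66 log units; beyond the scatter) and a 2.0-fold lower number from compound 1 to compound 3 (0.31 log units; beyond the scatter) and also a 2.2-fold higher number from compound 2 to compound 3 (0.35 log units; beyond the scatter) in this small set, all of them modest. None of them tests a methyl on an aromatic ring. On that evidence, a single added methyl is expected to give no step beyond the scatter in this assay in either direction. The expected step is a 1.1-fold lower number from compound 3 to compound 4 (0.04 log units; within the scatter) for this small change. For compound 4 the estimated value is 15000 nM with an expected range from 7000 nM to 32000 nM in this measurement.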

Compound 4, concentration for 50% growth inhibition: 11000 nM
The estimate for compound 4 lay 1.4-fold (0.13 log units) above the measured number, and the stated range covers the measured number.
By their numbers in this assay, from the lowest: compounds 2, 4 and 3 (each within the scatter of the next, the first and the last beyond it); then compound 1.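

In this assay, the methyl on the phenoxy ring gives a 1.5-fold lower number from compound 3 to compound 4 (0.18 log units; within the scatter) and so stays within the scatter, which means this single added carbon does not measurably change growth inhibition at this place on the ring. Compound 4 also shows a 1.5-fold higher number from compound 2 to compound 4 (0.17 log units; within the scatter) within the scatter and a 3.1-fold lower number from compound 1 to compound 4 (0.49 log units; beyond the scatter) beyond it, so the 3-(4-methylphenoxy)propyl chain keeps the clear separation from the phenyl side chain of compound 1. No measurement shown gives a reason for these numbers.

On these data alone, it remains open whether a larger group at this place, such as tert-butyl, or a carboxylic acid or an amine, would give a step beyond the scatter. A longer chain carrying the 4-methylphenoxy group is also an open case.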